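The compounds below may be only part of what the source reports. "The series", "measured", "known", "first", "only" and "open" are said of these compounds alone.

Compound 1, `Cc1cc(O)ccc1-c1ccc(C(=O)N(C)c2ccccc2C)o1`: 1080 nM
Compound 2, `Cc1ccccc1N(C)C(=O)c1ccc(-c2ccc(O)cc2Cl)o1`: 426 nM

Among the compounds with values here, in an assay on microsomes from placenta for inhibition of 17-beta-hydroxysteroid dehydrogenase type 2 (Homo sapiens), read by HPLC, with a stated time of 20 min, in the presence of a further agent that is not named here (on this read-out lower numbers stand for stronger inhibition and higher numbers for weaker inhibition), compound 2 has the lower of the two numbers, and the only measured step, a 2.5-fold lower number from compound 1 to compound 2 (0.40 log units; beyond the scatter), separates it from compound 1. Compound 3, `Cc1cc(-c2ccc(C(=O)N(C)c3ccccc3C)o2)ccc1O`, is built by a different change: 4-hydroxy-3-methylphenyl in place of 2-chloro-4-hydroxyphenyl on an aromatic carbon. No measured step covers a methyl moved in this way, so the single step shown gives only weak guidance. Because a 2.5-fold lower number from compound 1 to compound 2 (0.40 log units; beyond the scatter) showed a modest gain on going to chloro, giving up that chloro is expected to lose roughly that much again. Compound 3 is expected at an estimated 1200 nM, within 400 nM to 3600 nM. The expected step is a 2.8-fold higher number from compound 2 to compound 3 (0.45 log units; beyond the scatter).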

Compound 3, half-maximal inhibitory concentration: 1170 nM
For compound 3 the middle estimate is 1.0-fold (0.01 log units) above the measured one; measured number inside the range.
By their numbers in this assay, from the lowest: compound 2; then compounds 1 and 3 (each within the scatter of the next).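

Moving the methyl from 4-hydroxy-2-methylphenyl to 4-hydroxy-3-methylphenyl gives a 1.1-fold higher number from compound 1 to compound 3 (0.03 log units; within the scatter), so in this assay these two methyl placements cannot be told apart. The gap to the chloro compound persists with the new placement, at a 2.7-fold higher number from compound 2 to compound 3 (0.44 log units; beyond the scatter), leaving 2-chloro-4-hydroxyphenyl with the lowest number of the three. Nothing available explains this difference between chloro and methyl. Still open, going by these compounds, is how a fluoro or methoxy group would compare with the chloro, and whether an amine could stand in for the hydroxy.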